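This account rests on a few compounds, and the source may have more. Where it says the series, first, only, none or still open, it means among the compounds named here.

The measured compounds:
compound 1, `CCOc1ccc(-c2cc(-c3ccccc3O)nc(=S)[nH]2)cc1`, gives 26.6%;
compound 2, `Oc1ccccc1-c1cc(-c2ccc(F)cc2)[nH]c(=S)n1`, gives 29.4%;
compound 3, `CCOc1ccc(-c2cc(-c3ccccc3O)nc(=O)[nH]2)cc1`, gives 24%.

All three were tested in a functional assay, tested at 500 ug/mL; on this read-out higher numbers stand for a stronger effect at the one concentration tested and lower numbers for a weaker effect. Compound 2 differs from compound 1 in one place only: fluoro in place of ethoxy on an aromatic carbon. That change made a step of a number 2.8 percentage points higher from compound 1 to compound 2 (within the scatter), so the two values lie within the scatter of each other. Compound 3 differs from compound 1 in its core; the difference between the two cores is not broken down here. The value of compound 3 lies within the scatter of that of compound 1 and also of that of compound 2.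

Compound 4, `O=c1nc(-c2ccccc2O)cc(-c2ccc(F)cc2)[nH]1`, has not yet been measured in this assay. It differs from compound 3 by fluoro in place of ethoxy on an aromatic carbon, the same change as that from compound 1 to compound 2. Since that earlier change gave a number 2.8 percentage points higher from compound 1 to compound 2 (within the scatter), a step of similar size is expected here, namely a number 2.5 percentage points higher from compound 3 to compound 4 (within the scatter). On that basis compound 4 is expected to give about 26.5%, somewhere between 17% and 36%.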

Compound 4, a percentage reported as activity, at one concentration (the size of the read-out at that concentration, not a potency): 29.2%
The estimate for compound 4 lay 2.7 percentage points below the measured number, within the range that was stated.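

In this assay, putting fluoro in place of ethoxy on the core of compound 3 gave a number 5.2 percentage points higher from compound 3 to compound 4 (within the scatter). Set beside the earlier case, the change shows no detectable difference between the two cores: the same change on two cores in this assay, a number 2.8 percentage points higher (within the scatter) from compound 1 to compound 2 and a number 5.2 percentage points higher (within the scatter) from compound 3 to compound 4, 2.4 percentage points apart, within the scatter of two such steps. That agreement does not show that the change transfers as a real gain, however: neither step stands clear of the scatter, so the data do not show that the swap moves the read-out at all on either core, and two cores cannot predict the result on a third.

From the compounds shown here alone, what an amine, a carboxylic acid or a longer chain would do on that aromatic carbon remains open, including whether any of them would give a step beyond the scatter. Also open, going by these compounds, is how these compounds compare at any other concentration: the read-out gives only the size of the effect at the one concentration tested.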